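Removing the phenyl from the benzyl of compound 1

The compounds below may be only part of what the source reports. "The series", "measured", "known", "first", "only" and "open" are said of these compounds alone.

Measured so far, in an assay on isolated protein for inhibition of alpha-ketoglutarate-dependent dioxygenase alkB homolog 3 (Homo sapiens), read by polymerase chain reaction, with a stated time of 1 h; a lower number here means a stronger inhibitor, a higher number a weaker inhibitor:
compound 1 `Cc1[nH]n(-c2nc3c(C)cccc3[nH]2)c(=O)c1Cc1ccccc1` gives 5900 nM
compound 2 `Cc1[nH]n(-c2nc3ccccc3[nH]2)c(=O)c1Cc1ccc(-c2ccccc2)cc1` gives 720 nM

Among these two numbers compound 1 stands highest in this assay, and compound 2 sits well below it, a gap beyond the usual scatter. Compound 2 carries the larger group on the saturated chain carbon bound to an aromatic carbon, and its lower number is the only hint available about what that position tolerates.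

Compound 3 `Cc1[nH]n(-c2nc3c(C)cccc3[nH]2)c(=O)c1C` goes the other way: hydrogen in place of phenyl on a saturated chain carbon bound to an aromatic carbon. Among the measured compounds shown here, no measured pair shows this change directly, so the account is an expectation only. Since compound 1 already gives 5900 nM and the larger group of compound 2 gives the lower number, the step from compound 1 to compound 3 in this assay is expected to raise the number, likely beyond the scatter, as a 4.2-fold higher number from compound 1 to compound 3 (0.63 log units; beyond the scatter). Compound 3 is therefore estimated at 25000 nM, within a range from 7000 nM to 90000 nM, with a real chance that the assay reports only a limit.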

Compound 3, half-maximal inhibitory concentration: > 10000 nM
Compound 3 was reported as a limit; the forecaster's own chance of this, stated with the estimate: 35%; the middle value is on the limit's open side.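

In this assay compound 3 gives > 10000 nM, which is a limit and not a number. Among the compounds shown here, replacing the phenyl with hydrogen, which turns benzyl into methyl, now gives a first direct step at this position: an at least 1.6-fold higher number from compound 1 to compound 3 (0.22 log units; that floor lies within the scatter), and that floor alone does not establish a real loss. The full size of the step stays unresolved because the reading stops at a limit: the limit of > 10000 nM in this assay, at which 1 of the 3 values shown sits.

Compound 2 differs from compound 1 in more than one place, so it gives no clean reading of what a larger group on this saturated chain carbon contributes. Going by these compounds, how an amine, a carboxylic acid or a longer chain in place of the phenyl would read in this assay remains open.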